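Hydroxymethyl for ethoxycarbonyl: a second pairing in the series

The compounds below may be only part of what the source reports. "The series", "measured", "known", "first", "only" and "open" are said of these compounds alone.

Compound 1 `C=CC(=O)Nc1ccc(Cn2nc(-c3ccc(Oc4ccccc4)cc3)cc2C(=O)OCC)cc1` is the reference point. In a functional assay on Maver1 cells (Homo sapiens) for inhibition, read by luminescence and CellTiter-Glo, with a stated time of 72 h (on this read-out lower numbers stand for stronger inhibition and higher numbers for weaker inhibition), compound 1 gives 13300 nM. Compound 2 `C=CC(=O)Nc1cccc(Cn2nc(-c3ccc(Oc4ccccc4)cc3)cc2C(=O)OCC)c1` shares every atom with compound 1 but joins them differently; the difference between the two cores is 3-((vinylcarbonyl)amino)phenyl in place of 4-((vinylcarbonyl)amino)phenyl on a saturated chain carbon bound to an aromatic nitrogen. In this assay compound 2 gives 8600 nM, which amounts to a 1.5-fold lower number from compound 1 to compound 2 (0.19 log units; within the scatter). Compound 3 `C=CC(=O)Nc1ccc(Cn2nc(-c3ccc(Oc4ccccc4)cc3)cc2CO)cc1` carries the change hydroxymethyl in place of ethoxycarbonyl on an aromatic carbon relative to compound 1. In this assay compound 3 gives 7000 nM, a step of a 1.9-fold lower number from compound 1 to compound 3 (0.28 log units; within the scatter).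

Compound 4 `C=CC(=O)Nc1cccc(Cn2nc(-c3ccc(Oc4ccccc4)cc3)cc2CO)c1` is not yet measured. It differs from compound 2 by hydroxymethyl in place of ethoxycarbonyl on an aromatic carbon. The description of the place matches that of the pairing of compound 1 and compound 3 word for word, so this is the same change, and it occurs twice among these four compounds. Within the data shown here, only one measured example of it exists, and that example lies within the usual scatter, so any expectation rests on a single step of modest size.

In this assay, among the measured compounds shown here, the expected step is a 1.9-fold lower number from compound 2 to compound 4 (0.27 log units; within the scatter), set beside a 1.9-fold lower number from compound 1 to compound 3 (0.28 log units; within the scatter), because a 1.9-fold lower number from compound 1 to compound 3 (0.28 log units; within the scatter) is the only measured instance of this change and there is no reason in the data to expect the second instance to behave differently. Compound 4 is accordingly estimated at 4600 nM. The estimate for compound 4 is expected to span 2000 nM to 10500 nM.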

Compound 4, half-maximal inhibitory concentration: 6700 nM
The estimate for compound 4 lay 1.5-fold (0.16 log units) below the measured number; the range from low to high includes it.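

In this assay, hydroxymethyl in place of ethoxycarbonyl on the core bearing 3-((vinylcarbonyl)amino)phenyl gives a 1.3-fold lower number from compound 2 to compound 4 (0.11 log units; within the scatter), so the change can now be compared across both cores: the same change on two cores in this assay, a 1.9-fold lower number (0.28 log units; within the scatter) from compound 1 to compound 3 and a 1.3-fold lower number (0.11 log units; within the scatter) from compound 2 to compound 4, 1.5-fold (0.17 log units) apart, within the scatter of two such steps. Within this pair of cores, the change therefore carries over with no detectable difference in the size of the step, whether 3-((vinylcarbonyl)amino)phenyl or 4-((vinylcarbonyl)amino)phenyl is present. This does not establish that the change has any real effect on inhibition, as each step lies within the scatter on its own, and two cores give no basis for predicting the step on any other core in the series.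

Still open, going by these compounds, is whether any group on this aromatic carbon of the five-membered ring can move the number beyond the scatter, for example a carboxylic acid, a primary amide or an aminomethyl group in place of hydroxymethyl. Also open, on these data alone, is whether the same change would behave alike on cores where the phenoxyphenyl group is replaced or where a saturated propanoyl amide stands in place of the (vinylcarbonyl)amino group.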